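The source may hold more compounds than are shown below. What is called first, only, known or untested is meant among the compounds shown, and "the series" means these compounds.

Measured so far:
compound 1 `Cc1ccc(C2C(C#N)=C(N)N(c3ccc(S(N)(=O)=O)cc3)C3=C2C(=O)CCC3)cc1` — 30%
compound 2 `N#CC1=C(N)N(c2ccc(S(N)(=O)=O)cc2)C2=C(C(=O)CCC2)C1/C=C/c1ccccc1` — 10%

In a functional assay on Ehrlich cells (Mus musculus) for antiproliferative activity, read by trypan blue exclusion, with a stated time of 2 h, tested at 25 ug/mL (a lower number here means a weaker effect, a higher number a stronger effect of the compound at the concentration tested), compound 2 gives 10%, the lower of the two numbers; compound 1 gives 30%, and the step of a number 20 percentage points lower from compound 1 to compound 2 (beyond the scatter) lies beyond the scatter. Compound 3 `COc1cc(CC2C(C#N)=C(N)N(c3ccc(S(N)(=O)=O)cc3)C3=C2C(=O)CCC3)ccc1O` has not been measured. Its difference from compound 2 is 4-hydroxy-3-methoxybenzyl in place of 2-phenylethenyl on a saturated ring carbon.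

Going by the values given here, the one measured step that touches this saturated ring carbon is a number 20 percentage points lower from compound 1 to compound 2 (beyond the scatter): exchanging 4-methylphenyl for 2-phenylethenyl brought the number down. Compound 3 removes 2-phenylethenyl again, but 4-hydroxy-3-methoxybenzyl is neither of the two measured groups, so a full return to the level of compound 1 cannot be assumed. A modest rise is expected, a number 15 percentage points higher from compound 2 to compound 3 (beyond the scatter), with the possibility that the change stays within the scatter. Compound 3 is therefore estimated at 25% in this assay, with a range from 10% to 45%.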

Compound 3, a percentage reported as activity, at one concentration (the size of the read-out at that concentration, not a potency): 50%
Compound 3: middle estimate off by 25 percentage points, on the low side; the measured number lies above the stated range.
By their numbers in this assay, from the lowest: compound 2; then compound 1; then compound 3.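

In this assay the saturated ring carbon turns out to support a rise as well as a fall: a number 40 percentage points higher from compound 2 to compound 3 (beyond the scatter) is a large change, and a number 20 percentage points higher from compound 1 to compound 3 (beyond the scatter) places compound 3 clearly above compound 1 as well. All three groups carry one six-membered aromatic ring of carbon only, so that ring alone does not set the number, and the level depends on what surrounds it. Nothing on hand gives a reason for the rise.

Still open, as far as these compounds go, is which part of 4-hydroxy-3-methoxybenzyl matters, a question that plain benzyl, 4-hydroxybenzyl and 3-methoxybenzyl at this carbon would separate. Also open, from the compounds shown here alone, is how this position responds to a group without an aromatic ring, such as a short chain ending in an amine or a carboxylic acid.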